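Thiadiazolyl-to-triazinedione swap on the ring sulfur

The source may hold more compounds than are shown below. What is called first, only, known or untested is meant among the compounds shown, and "the series" means these compounds.

Compound 1 `CO[C@H]1C(=O)N2C(C(=O)C(C)(C)C)=C(C)C(Sc3nnc(C)s3)S(=O)(=O)[C@H]12` is one of two measured compounds. In a physicochemical assay for pharmacokinetics, at 37 degrees C (on this read-out lower numbers stand for a shorter-lived compound and higher numbers for a longer-lived compound), compound 1 gives 26 h, the lower of the two numbers. Compound 2 `CO[C@H]1C(=O)N2C(C(=O)C(C)(C)C)=C(CSc3nnc(C)s3)CS(=O)(=O)[C@H]12` gives 37 h in this assay, a gap that falls within the usual scatter, so the two stand level.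

Compound 3 `CO[C@H]1C(=O)N2C(C(=O)C(C)(C)C)=C(C)C(Sc3nc(=O)c(=O)[nH]n3C)S(=O)(=O)[C@H]12` differs from compound 1 in one place: a group of 9 heavy atoms (4 carbon, 3 nitrogen, 2 oxygen; one six-membered aromatic ring with 3 hetero atoms) in place of a group of 6 heavy atoms (3 carbon, 2 nitrogen, 1 sulfur; one five-membered aromatic ring with 3 hetero atoms), on a sulfur. Among the compounds with values here, no step between measured compounds covers such a change, so nothing here says which way this assay moves; a shift within the scatter, in either direction, is expected. The expected step from compound 1 to compound 3 is a 1.2-fold lower number from compound 1 to compound 3 (0.07 log units; within the scatter). Compound 3 is estimated at 22 h, with a range from 10 h to 50 h.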

Compound 3, half-life: 16.3 h
Beside the measured number, compound 3's estimate is 1.3-fold (0.13 log units) above it; the measured number falls inside the stated range.
By their numbers in this assay, from the lowest: compounds 3, 1 and 2 (each within the scatter of the next, the first and the last beyond it).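

The swap gives a 1.6-fold lower number from compound 1 to compound 3 (0.20 log units; within the scatter) in this assay, a step within the scatter. On a sulfur whose other neighbours are a saturated ring carbon, the 5-methyl-1,3,4-thiadiazol-2-yl group can thus give way to a six-membered aromatic ring with 3 hetero atoms and a hydrogen-bond donor, with the read-out staying level. Nothing measured here accounts for the step.

On these data alone, whether a carboxylic acid or an amine on this sulfur would also leave the half-life level stays open. So does whether the same swap holds on the core of compound 2.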